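Trading a trifluoromethyl for fluorine on compound 3

The source may report more compounds than this note shows. Statements on the series, on what has been measured and on what is new or still open speak of the compounds shown alone.

Of the compounds shown here, three have so far been measured in a functional assay on Huh-7 cells (Homo sapiens) for inhibition, read by sulforhodamine B assay, with a stated time of 72 h; on this read-out lower numbers stand for stronger inhibition and higher numbers for weaker inhibition. Compound 1, `CC(C)Cc1ccc(C(C)c2n[nH]c(=S)n2N)cc1`, is the smallest of them and in this assay gives 23000 nM. Compound 2, `COc1ccc2cc(C(C)c3nnc4n3N=C(c3ccc(Cl)cc3Cl)CS4)ccc2c1`, gives 10700 nM. Compound 3, `CC(c1ccc(-c2ccccc2)c(F)c1)c1nnc2n1N=C(c1ccc(C(F)(F)F)cc1)CS2`, gives 9400 nM, the lowest of the three numbers; its gap to compound 2 falls within the usual scatter of repeated measurements, so those two cannot be ordered, whereas its gap to compound 1 lies beyond that scatter.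

Compound 4, `CC(c1ccc(-c2ccccc2)c(F)c1)c1nnc2n1N=C(c1ccc(F)cc1)CS2`, has not yet been measured. It differs from compound 3 in a single place: fluoro in place of trifluoromethyl on an aromatic carbon. The trifluoromethyl group leaves and one fluorine takes its position on the aromatic ring, with the rest of the molecule kept as in compound 3.

Within the data shown here, no pair of measured compounds shows what this exchange does, so the expectation rests on the fact that everything else in compound 3 is unchanged. A step that stays within, or only just beyond, the scatter is expected, if anything toward a slightly higher number. In this assay the expected step is a 1.3-fold higher number from compound 3 to compound 4 (0.11 log units; within the scatter). Compound 4 is therefore estimated at 12000 nM, with a likely range from 5000 nM to 30000 nM.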

Compound 4, half-maximal inhibitory concentration: 4900 nM
The estimate for compound 4 lay 2.4-fold (0.39 log units) above the measured number, outside the stated range (below it).
By their numbers in this assay, from the lowest: compounds 4, 3 and 2 (each within the scatter of the next, the first and the last beyond it); then compound 1.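

Among these compounds, this is the first exchange that can be read directly, because only one place differs between the two compounds: in this assay the change from 4-(trifluoromethyl)phenyl to 4-fluorophenyl gives a 1.9-fold lower number from compound 3 to compound 4 (0.28 log units; within the scatter) as the step. That step stays inside the usual spread of repeat measurements, so the two compounds cannot be ordered, and at this position on the aromatic ring the group with far fewer heavy atoms reads the same as the larger one within that spread. Nothing measured here explains the size of this step or says what either group does at this position.

Going by these compounds, both groups seen at this position contain fluorine, so it remains open how the same place would read with a different kind of group, such as an amine, a carboxylic acid, a nitrile or a longer chain. On these data alone, it is also open whether fluoro in place of trifluoromethyl would give a similar step when the rest of the molecule differs, as it does in compound 2.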